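Pyrazine hydrazones: cytotoxicity read-out and an unmeasured nitrile

This account rests on a few compounds, and the source may have more. Where it says the series, first, only, none or still open, it means among the compounds named here.

Measured so far:
compound 1 `O=C(N/N=C/c1ccc(Cl)cc1)c1cnccn1` 56%
compound 2 `CCOc1ccc(/C=N/NC(=O)c2cnccn2)cc1` 100%

In an ADME assay on J774 cells (Mus musculus) for cytotoxicity, read by MTT assay, with a stated time of 48 h, tested at 150 ug/mL (a higher number here means a weaker effect of the compound at the concentration tested, a lower number a stronger effect), compound 2 stands highest of the two numbers; the nearest is compound 1, and the change a number 44 percentage points higher from compound 1 to compound 2 (beyond the scatter) is a large step beyond the scatter. Compound 3 `N#Cc1ccc(/C=N/NC(=O)c2cnccn2)cc1` differs from compound 2 by cyano in place of ethoxy on an aromatic carbon. Among the compounds with values here, only the step from compound 1 to compound 2 bears on this change, and it concerns chloro rather than cyano, so it guides only loosely. A moderate downward step a number 20 percentage points lower from compound 2 to compound 3 (beyond the scatter) is expected. Compound 3 is therefore estimated at 80%, ranging from 50% to 100%.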

Compound 3, a percentage reported as activity, at one concentration (the size of the read-out at that concentration, not a potency): 100%
Estimate against measurement, compound 3: 20 percentage points below; the measured number falls inside the stated range.
By their numbers in this assay, from the lowest: compound 1; then compounds 2 and 3 (each within the scatter of the next).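

In this assay, cyano in place of ethoxy at this position, para to a large group, gives no change at the digits printed from compound 2 to compound 3 (within the scatter), whereas cyano in place of chloro gives a number 44 percentage points higher from compound 1 to compound 3 (beyond the scatter). The read-out thus does not separate ethoxy from cyano here, and among these three groups only chloro stands apart. Nothing available explains this result. The compounds shown leave open whether an amine, a carboxylic acid or a longer chain at this position would read like chloro or like ethoxy and cyano.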